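This account rests on a few compounds, and the source may have more. Where it says the series, first, only, none or still open, it means among the compounds named here.

Measured so far:
- compound 1, `N=C(Nc1cccc(C(F)(F)F)c1)c1cc2c(-c3ccccc3)n[nH]c2cn1`: 24600 nM
- compound 2, `N=C(Nc1ccccc1)c1cc2c(-c3ccccc3)n[nH]c2c(NC2CCCCC2)n1`: 850 nM
- compound 3, `COc1cc(Nc2nc(C(=N)Nc3cccc(C(F)(F)F)c3)cc3c(-c4ccccc4)n[nH]c23)cc(OC)c1OC`: 6700 nM

All three were tested in a functional assay on HT-1080 cells (Homo sapiens) for cytotoxicity, read by MTT assay, with a stated time of 72 h; on this read-out lower numbers stand for stronger inhibition and higher numbers for weaker inhibition. Compound 3 stands second highest of the three numbers. Its nearest neighbour is compound 1, whose number is higher by an amount beyond the usual scatter, so compound 3 is the stronger of the two. Its furthest neighbour is compound 2, whose number is lower by a margin also beyond the scatter, so compound 2 is the stronger of that pair.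

Compound 4, `N=C(Nc1cccc(C(F)(F)F)c1)c1cc2c(-c3ccccc3)n[nH]c2c(NC2CCCCC2)n1`, has not yet been measured in this assay. It differs from compound 3 in one place: cyclohexyl in place of 3,4,5-trimethoxyphenyl on a nitrogen on an aromatic ring. The nitrogen on the aromatic ring keeps its place; only what hangs from it changes.

For the measured compounds named here, no measured pair shows exactly this change. Compound 2 carries the same cyclohexyl on that nitrogen, and in this assay compound 2 gives 850 nM, while compound 3 with the trimethoxyphenyl gives 6700 nM. A step towards a lower number is therefore expected from compound 3 to compound 4, estimated at a 4.5-fold lower number from compound 3 to compound 4 (0.65 log units; beyond the scatter), because compound 2 reaches 850 nM. For compound 4 the expected value in this assay is 1500 nM, within a range of 400 nM to 6000 nM.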

Compound 4, half-maximal inhibitory concentration: 21200 nM
Compound 4: middle estimate off by 14-fold (1.15 log units), on the low side, and the stated range ends below it.
By their numbers in this assay, from the lowest: compound 2; then compound 3; then compounds 4 and 1 (each within the scatter of the next).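

In this assay, putting cyclohexyl in place of 3,4,5-trimethoxyphenyl on the nitrogen gives a 3.2-fold higher number from compound 3 to compound 4 (0.50 log units; beyond the scatter), so among compounds carrying trifluoromethyl, the trimethoxyphenyl version is the stronger of this pair. Cyclohexylamino in place of hydrogen on an aromatic carbon gives a 1.2-fold lower number from compound 1 to compound 4 (0.06 log units; within the scatter), a step within the scatter, so with trifluoromethyl present this group brings no measurable gain. The largest step is trifluoromethyl in place of hydrogen on an aromatic carbon, a 25-fold higher number from compound 2 to compound 4 (1.40 log units; beyond the scatter), which shows that the strong result of compound 2 does not carry over to a compound with trifluoromethyl, so the effect of a group on the nitrogen cannot be assumed to be the same whichever other groups are present.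

Still open, from the compounds shown here alone, is whether trimethoxyphenyl would also beat cyclohexyl in a compound with hydrogen in place of trifluoromethyl, and how a morpholine or a dimethylamino group would fare on this aromatic carbon. Nothing shown here accounts for the way these two groups depend on each other.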